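Methoxy to (Trifluoromethyl)sulfanyl on a Shared Core

A few compounds are considered here, and "the series" means these few. Any claim that something is new, unique, unknown or untested is made for them only; others in the source may bear on it.

Of the compounds shown here, two on the shared core have been measured in a functional assay on A549 cells (Homo sapiens) for antiproliferative activity, read by MTT assay, with a stated time of 72 h; a higher number here means a weaker inhibitor, a lower number a stronger inhibitor. Compound 1 `Cc1ccc(NC(=O)C(Cl)Cl)cc1` gives 48900 nM; compound 2 `COc1ccc(NC(=O)C(Cl)Cl)cc1` gives 80900 nM, and the step of a 1.7-fold higher number from compound 1 to compound 2 (0.22 log units; within the scatter) keeps both numbers within the scatter of each other. Compound 3 `O=C(Nc1ccc(SC(F)(F)F)cc1)C(Cl)Cl` differs from compound 2 by (trifluoromethyl)sulfanyl in place of methoxy on an aromatic carbon. Among the compounds with values here, no measured step involves this group, and the one step in hand stayed within the scatter, so no change beyond the scatter is expected in this assay. Compound 3 is estimated at 55000 nM, between 15000 nM and 200000 nM, an expected step of a 1.5-fold lower number from compound 2 to compound 3 (0.17 log units; within the scatter).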

Compound 3, half-maximal inhibitory concentration: 10600 nM
Beside the measured number, compound 3's estimate is 5.2-fold (0.72 log units) above it; the whole stated range lies above it.
By their numbers in this assay, from the lowest: compound 3; then compounds 1 and 2 (each within the scatter of the next).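

On this aromatic carbon, this assay now shows a change that goes beyond the scatter, which the step between methyl and methoxy did not: a 7.6-fold lower number from compound 2 to compound 3 (0.88 log units; beyond the scatter) with (trifluoromethyl)sulfanyl in place of methoxy, and a 4.6-fold lower number from compound 1 to compound 3 (0.66 log units; beyond the scatter) with it in place of methyl. Both steps are modest and run in the same direction. No evidence is at hand to explain this result.

Going by these compounds, whether an amine, a carboxylic acid or a longer chain on this carbon would lower the number further remains open. So does whether a plain methylsulfanyl group would give the same result.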